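Exchanging the aryl group on a sulfonamide nitrogen

A few compounds are considered here, and "the series" means these few. Any claim that something is new, unique, unknown or untested is made for them only; others in the source may bear on it.

In a physicochemical assay for lipophilicity, at pH 7.4 (on this read-out lower numbers stand for lower lipophilicity and higher numbers for higher lipophilicity), compound 2 `Cc1ccc(N(CC(C)C)S(=O)(=O)c2ccc3c(c2)C(=O)CC(C2CCOCC2)O3)c(C)c1` gives 4.28 and stands level, within the scatter, with compound 1 `CC(C)CN(C1CCc2ccc(F)cc21)S(=O)(=O)c1ccc2c(c1)C(=O)CC(C1CCOCC1)O2` at 4.03 while lying well above compound 3 `Cc1ccc(NS(=O)(=O)c2ccc3c(c2)C(=O)CC(C2CCOCC2)O3)c(C)c1` at 2.75 on this scale.

Compound 4 `CC(C)CN(c1ccc(F)cc1F)S(=O)(=O)c1ccc2c(c1)C(=O)CC(C1CCOCC1)O2` has not yet been measured. Its difference from compound 2 is 2,4-difluorophenyl in place of 2,4-dimethylphenyl on a sulfonamide nitrogen with 2,4-difluorophenyl in place of 2,4-dimethylphenyl on a sulfonamide nitrogen.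

Among the measured compounds shown here, two measured steps bear on this change. The closer one is a number 0.25 log units higher from compound 1 to compound 2 (within the scatter) and it also exchanges the group that compound 4 alters, leaving isobutyl in place. The other, a number 1.53 log units lower from compound 2 to compound 3 (beyond the scatter) is large, but it removes the isobutyl, which compound 4 retains, so it says little about the size of this change. For the measured compounds named here, no measured step makes this exact exchange, so the data give its direction only weakly. A moderate fall is expected, and the estimate is a number 0.53 log units lower from compound 2 to compound 4 (beyond the scatter) for this change. Compound 4 is expected at 3.75 with an estimated range from 3.3 to 4.2 in this assay when it is measured.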

Compound 4, distribution coefficient: 3.62
For compound 4 the middle estimate is 0.13 log units above the measured one; low and high end bracket the measured number.
By their numbers in this assay, from the lowest: compound 3; then compound 4; then compounds 1 and 2 (each within the scatter of the next).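

In this assay, exchanging the aryl group on the sulfonamide nitrogen now gives a change beyond the scatter: 2,4-difluorophenyl in place of 2,4-dimethylphenyl gives a number 0.66 log units lower from compound 2 to compound 4 (beyond the scatter), whereas the earlier exchange at this position, between the 6-fluoro-2,3-dihydro-1H-inden-1-yl and 2,4-dimethylphenyl groups, stayed within it. The 2,4-difluorophenyl group also stands apart from the 6-fluoro-2,3-dihydro-1H-inden-1-yl group, with a number 0.41 log units lower from compound 1 to compound 4 (beyond the scatter), so with isobutyl held in place the read-out does depend on the group at this position. Nothing available gives a reason for these differences.

As far as these compounds go, it remains open how the read-out would move with a carboxylic acid or an amine on the phenyl ring at this nitrogen. Also open, from the compounds shown here alone, is whether the exchange to 2,4-difluorophenyl would give a similar step with hydrogen in place of isobutyl, as in compound 3.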